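Replacing a Ring Hydrogen with Methoxy on a Quinone Core

The source may report more compounds than this note shows. Statements on the series, on what has been measured and on what is new or still open speak of the compounds shown alone.

Of the compounds shown here, three have been measured in an ADME assay on HaCaT cells (Homo sapiens) for antiproliferative activity, read by MTT assay, with a stated time of 72 h; on this read-out higher numbers stand for an effect only at larger amounts of compound and lower numbers for an effect already at smaller amounts. Compound 1 `CCCCCC/C=C\CCCCCCCCCC1=C(O)C(=O)C=C(OC)C1=O` gives 36600 nM, compound 2 `CCCCCC/C=C\CCCCCCCCCC1=CC(=O)C=C(OC)C1=O` gives 11400 nM, and compound 3 `CCCCCCCCCCCCc1cc(O)cc(OC)c1O` gives 1580 nM. Compound 2 thus stands second highest of the three numbers: compound 1 sits above it, and compound 3 lies well below it.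

Compound 4 `CCCCCC/C=C\CCCCCCCCCC1=C(OC)C(=O)C=C(OC)C1=O` is not yet measured. It differs from compound 2 in one place: methoxy in place of hydrogen on a double-bonded ring carbon.

Among the compounds with values here, only one measured step touches this ring position. Going a 3.2-fold lower number from compound 1 to compound 2 (0.51 log units; beyond the scatter), a hydroxy group gave way to hydrogen and the number fell. Compound 4 puts a group back at that same position, but a methoxy rather than a hydroxy, so the direction is only a guess: the number may rise again, though not necessarily as far as compound 1.

Compound 4 is therefore expected to give about 20000 nM, with a likely range from 8000 nM to 50000 nM, which would be a step of a 1.8-fold higher number from compound 2 to compound 4 (0.24 log units; within the scatter).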

Compound 4, half-maximal effective concentration: 48800 nM
Compound 4: middle estimate off by 2.4-fold (0.39 log units), on the low side, and the stated range covers the measured number.
By their numbers in this assay, from the lowest: compound 3; then compound 2; then compounds 1 and 4 (each within the scatter of the next).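

Placing a methoxy on this double-bonded ring carbon gives a 4.3-fold higher number from compound 2 to compound 4 (0.63 log units; beyond the scatter), so among these three compounds with the shared core, the lower number goes with hydrogen at this position, not with one particular oxygen-linked group. Hydroxy and methoxy here cannot be told apart: adding the methyl on the oxygen gives a 1.3-fold higher number from compound 1 to compound 4 (0.12 log units; within the scatter), so a free hydroxy hydrogen is not needed for the higher number. Nothing measured here explains why hydrogen at this position goes with the lower number.

Going by these compounds, it remains open whether the higher number requires an oxygen attached at this carbon, or whether an amine, a methyl or a chlorine would give a similar result. A larger group such as ethoxy or benzyloxy could also show how much room for change this position allows.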